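The source may hold more compounds than are shown below. What is called first, only, known or untested is meant among the compounds shown, and "the series" means these compounds.

Measured compounds:
Compound 1 `Cc1ccccc1Nc1nc(C)c(C(=O)/C=C/c2ccc(Cl)cc2)s1`: in a functional assay on BGC-823 cells (Homo sapiens) for cytotoxicity, read by MTT assay (on this read-out higher numbers stand for weaker inhibition and lower numbers for stronger inhibition), compound 1 gives > 25000 nM, which is a limit of the assay.
Compound 2 `COc1cccc(/C=C/C(=O)c2sc(Nc3ccccc3C)nc2C)c1`: in this assay compound 2 gives > 25000 nM, likewise a limit.

Among the compounds with values here, compound 1 stands at a limit in this assay, so no number is known for it; the one further value is a limit as well, and both values sit at the limit of > 25000 nM in this assay, at which 2 of the 2 values shown sit. Within the data shown here, the single measured step, a step that the two limits leave unreadable from compound 1 to compound 2, runs between two limits and its size cannot be read. Compound 3 `Cc1cccc(Nc2nc(C)c(C(=O)/C=C/c3ccc(Cl)cc3)s2)c1` differs from compound 1 by 3-methylphenyl in place of 2-methylphenyl on a nitrogen on an aromatic ring. Among the measured compounds shown here, no measured step bears on this change: the only step concerns the aryl on the double-bonded chain carbon and is itself unreadable. What the series shows is that neither measured member gave a readable number in this assay, and nothing among the values suggests that compound 3 will. Compound 3 is therefore expected to give about 30000 nM, with a range of 10000 nM to 100000 nM. This expectation corresponds to an estimated step that the limit leaves unreadable from compound 1 to compound 3. It is expected that the assay will most likely once more report only a limit.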

Compound 3, half-maximal inhibitory concentration: > 25000 nM
Compound 3 ended at the assay's limit; the forecaster's own chance of this, stated with the estimate: 75%; the middle value does not contradict the limit.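

In this assay compound 3 gives > 25000 nM, a limit of the assay. Compound 3 and compound 1 therefore yield no readable step, and the series stays at one value: the limit of > 25000 nM in this assay, at which 3 of the 3 values shown sit.

The compounds shown leave open whether any change on the shared core gives a readable number in this assay.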